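Ortho-substituent swap on the aryl ring of the ester series

The source may hold more compounds than are shown below. What is called first, only, known or untested is meant among the compounds shown, and "the series" means these compounds.

Measured so far:
- compound 1 `O=C(O)c1cnc(-c2cccc(C(F)(F)F)c2)[nH]c1=O`: 33 mg/kg
- compound 2 `CCOC(=O)c1cnc(-c2ccccc2Cl)[nH]c1=O`: 5 mg/kg

In a functional assay on the whole organism (strain Sprague-Dawley) for inhibition, with Rattus norvegicus as the target, with a stated time of 10 min (on this read-out lower numbers stand for an effect already at smaller amounts and higher numbers for an effect only at larger amounts of compound), compound 2 gives 5 mg/kg, the lowest of the two numbers. In this assay compound 1 gives 33 mg/kg, a higher number than that of compound 2, and the gap between the two lies beyond the scatter. Since compound 1 and compound 2 differ in more than one place, no single-change step can be read from them.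

Compound 3 `CCOC(=O)c1cnc(-c2ccccc2OCc2ccccc2)[nH]c1=O` is the next compound for this assay. It differs from compound 2 in one place: benzyloxy in place of chloro on an aromatic carbon. Among the measured compounds shown here, no step between measured compounds resembles this change, so the direction is open. The expectation is a modest rise in the number, possibly within the scatter, giving a 1.6-fold higher number from compound 2 to compound 3 (0.20 log units; within the scatter). Compound 3 is accordingly estimated at 8 mg/kg, with a range from 2.5 mg/kg to 25 mg/kg.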

Compound 3, dose for 50% inhibition: > 5 mg/kg
Compound 3 gave a limit, no number; the forecaster's own chance of this, stated with the estimate: 10%; the middle value is on the limit's open side.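

In this assay compound 3 gives a limit, > 5 mg/kg, and not a number. Benzyloxy in place of chloro, on an aromatic carbon ortho to a large group, is the first change at this position that can be read, and it gives a number no lower from compound 2 to compound 3 (the limit leaves the size open); the entering group adds a six-membered aromatic ring of carbon only and one hydrogen-bond acceptor, with no lower number in return. This reading rests on a single value that is not a number: the limit of > 5 mg/kg in this assay, at which 1 of the 3 values shown sits.

As far as these compounds go, how far compound 3 lies from compound 2 stays open, so the change may be anything from no real shift to a large loss. Also open, from the compounds shown here alone, is whether methoxy or an amine on this same aromatic carbon would hold, lower or raise the number given by the chloro ester.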